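This account rests on a few compounds, and the source may have more. Where it says the series, first, only, none or still open, it means among the compounds named here.

Measured so far in a functional assay on A549 cells (Homo sapiens) for cytotoxicity, read by MTT assay, with a stated time of 48 h; a lower number here means a stronger inhibitor, a higher number a weaker inhibitor:
compound 1 `O=C(/C=C\Nc1ccc(Cl)cc1)c1nc(-c2ccc(C(F)(F)F)cc2)n2ccccc12`: 18500 nM
compound 2 `O=C(/C=C\Nc1ccc(F)cc1)c1nc(-c2ccc(C(F)(F)F)cc2)n2ccccc12`: > 30000 nM, a limit of the assay
compound 3 `COc1ccc(N/C=C\C(=O)c2nc(-c3ccccc3)n3ccccc23)cc1`: > 30000 nM, a limit of the assay

Compound 3 thus stands at the upper limit, where two of the three values sit (the limit of > 30000 nM in this assay, at which 2 of the 3 values shown sit). For the measured compounds named here, the only measured step, an at least 1.6-fold higher number from compound 1 to compound 2 (0.20 log units; that floor lies within the scatter), concerns the halogen on an aromatic carbon and does not bear on the change to compound 4 `COc1ccc(N/C=C\C(=O)c2nc(-c3ccc(C(F)(F)F)cc3)n3ccccc23)cc1`, which is trifluoromethyl in place of hydrogen on an aromatic carbon. Going by the values given here, no measured pair shows this change. Compounds 1 and 2 already carry the trifluoromethyl group and both give weak values. For compound 4 the step of a number no higher from compound 3 to compound 4 (the limit leaves the size open) is therefore expected to be none beyond the scatter. The estimate for compound 4 in this assay is 30000 nM, within 12000 nM to 60000 nM, most likely reported again only as a limit.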

Compound 4, half-maximal inhibitory concentration: 21800 nM
Compound 4: the middle estimate sits 1.4-fold (0.14 log units) above what was measured; low and high end bracket the measured number.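

In this assay, trifluoromethyl in place of hydrogen at this position gives an at least 1.3-fold lower number from compound 3 to compound 4 (0.13 log units; that floor lies within the scatter), so the change yields a measured number but shows no gain beyond the scatter. With trifluoromethyl in place, methoxy in place of fluoro gives an at least 1.3-fold lower number from compound 2 to compound 4 (0.13 log units; that floor lies within the scatter), and methoxy in place of chloro gives a 1.2-fold higher number from compound 1 to compound 4 (0.07 log units; within the scatter), so these groups are not separated here. Compound 2 and compound 3 remain limits of the assay: the limit of > 30000 nM in this assay, at which 2 of the 4 values shown sit.

Open, as far as these compounds go, is whether an amine or a carboxylic acid at the trifluoromethyl position would move the number beyond the scatter. From the compounds shown here alone, the full size of the two steps that start from a limit also stays open.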